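Swapping Methoxy for Methyl on an Inactive Scaffold

A few compounds are considered here, and "the series" means these few. Any claim that something is new, unique, unknown or untested is made for them only; others in the source may bear on it.

Compound 1 `C=C1C[C@]23C[C@@]1(O)CC[C@@H]2c1cccc(C)c1[C@@H]3Cn1cc(-c2ccc(OC)cc2)nn1` carries a shared core and a 4-methoxyphenyl group. In a functional assay on SMMC-7721 cells (Homo sapiens) for cytotoxicity, read by MTT assay, with a stated time of 4 days (a lower number here means a stronger inhibitor, a higher number a weaker inhibitor), compound 1 gives > 20000 nM, which is a limit of the assay and not a number. Compound 3 `C=C1C[C@]23C[C@@]1(O)CC[C@@H]2c1cccc(C)c1[C@@H]3Cn1cc(-c2ccc(C)cc2)nn1` differs from compound 1 in only one place: methyl in place of methoxy on an aromatic carbon. In this assay compound 3 gives > 20000 nM, again a limit rather than a number. The step that the two limits leave unreadable from compound 1 to compound 3 therefore cannot be read, because both of its ends sit at the limit of > 20000 nM in this assay, at which 3 of the 3 values shown sit.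

Compound 2 `C=C1C[C@]23C[C@@]1(O)CC[C@H]2c1ccc(O)c(C)c1[C@@H]3Cn1cc(-c2ccc(OC)cc2)nn1` has a different core from compound 1; the difference between the two cores is not broken down here. In this assay compound 2 gives > 20000 nM, a limit and not a number.

Compound 4 `C=C1C[C@]23C[C@@]1(O)CC[C@H]2c1ccc(O)c(C)c1[C@@H]3Cn1cc(-c2ccc(C)cc2)nn1` has not yet been measured. It is related to compound 2 by the same change that turns compound 1 into compound 3: methyl in place of methoxy on an aromatic carbon. None of the three measured compounds shows any movement away from the limit, so the expectation for compound 4 rests only on their shared position. In this assay the expected step is a step that the limit leaves unreadable from compound 2 to compound 4, judged small, because the limit of > 20000 nM in this assay, at which 3 of the 3 values shown sit, is where every measured value stands. Compound 4 is therefore estimated at 30000 nM, with a range from 15000 nM to 80000 nM, and it is expected that the measurement will most likely again be reported only as a limit.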

Compound 4, half-maximal inhibitory concentration: > 20000 nM
Compound 4 ended at the assay's limit (the forecaster's own chance of this, stated with the estimate: 90%); the middle value does not contradict the limit.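

No new step can be read: compound 2 and compound 4 both sit at a limit of the assay and not at a number, so the swap of methoxy for methyl cannot be sized between them: the limit of > 20000 nM in this assay, at which 4 of the 4 values shown sit.

The compounds shown leave open whether this swap, or the difference between the cores, has any effect on the read-out in this assay.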